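Swapping the Fluorophenyl Arm for a Pyridine Ring

The source may report more compounds than this note shows. Statements on the series, on what has been measured and on what is new or still open speak of the compounds shown alone.

Compound 1, `CCC(Sc1nc2c(cnn2C)c(=O)n1-c1ccccc1)c1ccccc1`, gives 179 nM in an assay on isolated protein for inhibition of retinal dehydrogenase 2 (Homo sapiens); on this read-out lower numbers stand for stronger inhibition and higher numbers for weaker inhibition.
Compound 2, `COc1cccc(C(C)Sc2nc3c(cnn3C)c(=O)n2-c2ccccc2)c1`, gives 108 nM in this assay.
Compound 3, `CC(Sc1nc2c(cnn2C)c(=O)n1-c1ccccc1)c1cccc(F)c1`, gives 110 nM in this assay.

Compound 3 sits second highest of these three numbers, but all three lie close together. Its nearest neighbour is compound 2, the step being a 1.0-fold higher number from compound 2 to compound 3 (0.01 log units; within the scatter). Its furthest is compound 1, where the step is a 1.6-fold lower number from compound 1 to compound 3 (0.21 log units; within the scatter). Both steps stay within the scatter, so the three compounds cannot be ranked against one another.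

Compound 4, `CC(Sc1nc2c(cnn2C)c(=O)n1-c1ccccc1)c1cccnc1`, has not yet been measured. The change from compound 3 is pyridin-3-yl in place of 3-fluorophenyl on a saturated chain carbon bound to a saturated chain carbon and a sulfur. Going by the values given here, no measured step exchanges a ring carbon for a ring nitrogen, so no direct precedent exists. The two steps that do touch this arm, from compound 1 and from compound 2, each stayed within the scatter, suggesting the arm tolerates variation. The step is therefore expected to be a 1.3-fold higher number from compound 3 to compound 4 (0.10 log units; within the scatter). Compound 4 is expected to give about 140 nM, with a likely range from 60 nM to 330 nM.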

Compound 4, half-maximal inhibitory concentration: 89 nM
For compound 4 the middle estimate is 1.6-fold (0.20 log units) above the measured one, and the stated range covers the measured number.
By their numbers in this assay, from the lowest: compounds 4, 2, 3 and 1 (each within the scatter of the next).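

In compounds 1, 2 and 3 the ring on this arm is of carbon only, whereas pyridin-3-yl brings a ring with one hetero atom and counts one hydrogen-bond acceptor where 3-fluorophenyl counts none, yet this assay shows a 1.2-fold lower number from compound 3 to compound 4 (0.09 log units; within the scatter). The comparison with the 3-methoxyphenyl compound reads the same, a 1.2-fold lower number from compound 2 to compound 4 (0.08 log units; within the scatter), and even the largest step in the set, a 2.0-fold lower number from compound 1 to compound 4 (0.30 log units; within the scatter), does not leave the scatter, so the four compounds still cannot be ranked. Nothing available explains why this exchange of rings leaves the number within the scatter.

Going by these compounds, what pyridin-4-yl, or a phenyl ring carrying an amine or a carboxylic acid, would give at this position remains open. So does whether any change on this arm can move the number beyond the scatter.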